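A few compounds are considered here, and "the series" means these few. Any claim that something is new, unique, unknown or untested is made for them only; others in the source may bear on it.

Measured so far:
compound 1 `COc1cc2c(cc1OC)C(CC(=O)NC(C)(C)C)CC2` — 31.5%
compound 2 `COc1cc2c(cc1OC)C(CC(=O)N1CCCCC1)CC2` — 31.5%

In a functional assay on the whole organism (strain Wistar) for inhibition, with Rattus norvegicus as the target, read by paw edema, with stated times of 60 min and 6 h, at a dose of 100 mg/kg by the oral route (on this read-out higher numbers stand for more inhibition at the one dose given (going by the name of the read-out) and lower numbers for less inhibition), compound 2 gives 31.5%, level at the digits shown with compound 1, the only other measured member of the series. For the measured compounds named here, the one measured step, no change at the digits printed from compound 1 to compound 2 (within the scatter), also exchanges the group on the carbonyl carbon and lies within the scatter.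

Compound 3 `COc1cc2c(cc1OC)C(CC(=O)N1CCNCC1)CC2` is not yet measured. Its difference from compound 2: piperazin-1-yl in place of piperidin-1-yl on a carbonyl carbon. This is a further exchange of the amine on the carbonyl carbon, the position that was already varied in no change at the digits printed from compound 1 to compound 2 (within the scatter) without any effect beyond the scatter. Going by the values given here, that step is the only one bearing on the question; no measured pair shows how a ring with two hetero atoms and one hydrogen-bond donor behaves at this place, so the expectation rests on that single step alone. In this assay the step is expected to be no change at the digits printed from compound 2 to compound 3 (within the scatter), nothing beyond the scatter. Compound 3 is therefore estimated at 31.5%, with a range of 15% to 45%.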

Compound 3, a percentage reported as inhibition, in the whole organism at one dose (the size of the read-out at that dose, not a potency): 33.3%
The estimate for compound 3 lay 1.8 percentage points below the measured number; low and high end bracket the measured number.
By their numbers in this assay, from the lowest: compounds 1, 2 and 3 (each within the scatter of the next).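

In this assay the change to piperazin-1-yl on the carbonyl carbon gives a number 1.8 percentage points higher from compound 2 to compound 3 (within the scatter) and, set against the (tert-butyl)amino group, a number 1.8 percentage points higher from compound 1 to compound 3 (within the scatter), so all three amines at this place stand within the scatter of each other. What compound 3 adds is that a second ring nitrogen, with 1 hydrogen-bond donor and 1 hydrogen-bond acceptor entering where piperidin-1-yl has neither, also gives no step beyond the scatter at this dose. Nothing on hand accounts for this flat read-out.

Going by these compounds, whether any group on the carbonyl carbon can move the number beyond the scatter remains open, for instance a morpholin-4-yl group or a piperazine carrying a benzyl group on its second nitrogen. The three compounds share the same core and saturated chain, so a longer chain or a free carboxylic acid in place of the amide remains unread.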